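A few compounds are considered here, and "the series" means these few. Any claim that something is new, unique, unknown or untested is made for them only; others in the source may bear on it.

In an ADME assay on THP-1 cells (Homo sapiens) for cytotoxicity, read by MTT assay, with a stated time of 72 h (on this read-out higher numbers stand for an effect only at larger amounts of compound and lower numbers for an effect already at smaller amounts), compound 1, with the structure `O=c1nc(-c2ccccc2)c2cc(-c3ccc(N4CCCC4)nc3)ccc2[nH]1`, gives > 50000 nM, which is a limit of the assay rather than a number. Compound 2, with the structure `O=c1nc(-c2ccccc2)c2cc(-c3ccc(F)cc3)ccc2[nH]1`, gives > 50000 nM in this assay, again a limit and not a number. Going by the values given here, both values sit at the same boundary, as the line the limit of > 50000 nM in this assay, at which 2 of the 2 values shown sit, shows, so compound 2 stands where every value so far stands, with no number to rank it against. Compound 3, with the structure `O=c1nc(-c2ccccc2)c2cc(N3CCNCC3)ccc2[nH]1`, has not yet been measured in this assay. It differs from compound 2 in one place: piperazin-1-yl in place of 4-fluorophenyl on an aromatic carbon. Among the compounds with values here, with no step between measured compounds to draw on, he expects no step in this assay beyond the usual scatter, and estimates the change from compound 2 to compound 3 as a step that the limit leaves unreadable from compound 2 to compound 3. For compound 3 he therefore expects a value of about 60000 nM in this assay, within a range from 25000 nM to 150000 nM.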

Compound 3, half-maximal effective concentration: > 25000 nM
Compound 3 was reported as a limit; the forecaster's own chance of this, stated with the estimate: 75%; the middle value does not contradict the limit.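

In this assay no step can be read from compound 2 to compound 3, as both are reported only as limits of the assay and not as numbers. The compounds shown leave open at what concentration any of them reaches a half-maximal effect, and whether piperazin-1-yl in place of 4-fluorophenyl changes that concentration at all.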